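The source may hold more compounds than are shown below. What is called first, only, known or untested is meant among the compounds shown, and "the series" means these compounds.

Measured in a functional assay on HSC-4 cells (Homo sapiens) for cytotoxicity, with a stated time of 24 h; on this read-out higher numbers stand for lower toxicity in this test and lower numbers for higher toxicity in this test:
- Compound 1 `CN(C)c1ccc(/C=C2\CCC/C(=C\c3ccccc3[N+](=O)[O-])C2=O)cc1` gives > 400000 nM, which is a limit of the assay.
- Compound 2 `O=C1/C(=C/c2ccccc2)CCC/C1=C\c1ccc([N+](=O)[O-])cc1` gives 9200 nM.
- Compound 3 `O=C1/C(=C/c2ccc(F)cc2)CCC/C1=C\c1ccc([N+](=O)[O-])cc1` gives 15000 nM.

Compound 3 lies within the scatter of compound 2, and the other entry is only a limit. The next change leads to compound 4 `O=C1/C(=C/c2ccc(Cl)cc2)CCC/C1=C\c1ccc([N+](=O)[O-])cc1`: chloro in place of fluoro on an aromatic carbon, para to a large group. Among the measured compounds shown here, the one measured step that bears on this is a 1.6-fold higher number from compound 2 to compound 3 (0.21 log units; within the scatter), fluoro in place of hydrogen on an aromatic carbon. That step stays within the scatter, so no change beyond the scatter is expected in this assay and no direction is favoured. The expected step is a 1.2-fold lower number from compound 3 to compound 4 (0.06 log units; within the scatter). For compound 4 the estimated value is 13000 nM, with an expected range from 5000 nM to 35000 nM.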

Compound 4, half-maximal cytotoxic concentration: 2700 nM
For compound 4 the middle estimate is 4.8-fold (0.68 log units) above the measured one; the measured number lies below the stated range.
By their numbers in this assay, from the lowest: compound 4; then compounds 2 and 3 (each within the scatter of the next). At a limit, above all of these: compound 1.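

In this assay the group on this aromatic carbon, para to a large group, now makes a difference: the change from 4-fluorophenyl to 4-chlorophenyl brings a 5.6-fold lower number from compound 3 to compound 4 (0.74 log units; beyond the scatter), whereas fluoro in place of hydrogen stayed within the scatter. Chloro in place of hydrogen brings a 3.4-fold lower number from compound 2 to compound 4 (0.53 log units; beyond the scatter), so chloro sets compound 4 apart from both compound 2 and compound 3. Nothing shown accounts for this step.

Going by these compounds, whether bromo or methoxy on this carbon would follow chloro or fluoro remains open. Also open, on these data alone, is whether the chloro step holds when the nitro group on the other ring is replaced by an amine.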